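A few compounds are considered here, and "the series" means these few. Any claim that something is new, unique, unknown or untested is made for them only; others in the source may bear on it.

Three compounds of one series have numbers in an assay on CHO cells for displacement of a labelled ligand from adenosine receptor A1 (Homo sapiens), read by scintillation counting, with a stated time of 1 h, tested at 1 uM; on this read-out lower numbers stand for less inhibition and higher numbers for more inhibition at the one concentration tested (going by the name of the read-out). Compound 1 `Nc1ncc(-c2cccc(F)c2)c(-c2ccccc2)n1` gives 63%, compound 2 `COc1cc(-c2cnc(N)nc2-c2ccccc2)cc(OC)c1OC` gives 56%, and compound 3 `O=C(Nc1ncc(-c2cccc(Cl)c2)c(-c2ccccc2)n1)C1CCC1` gives 52%. Compound 3 stands lowest of the three; its number sits within the scatter of that of compound 2 and beyond the scatter of that of compound 1. Compound 4 `Clc1cccc(-c2cnc(NCCCc3ccccc3)nc2-c2ccccc2)c1` is not yet measured; it differs from compound 3 by 3-phenylpropyl in place of cyclobutylcarbonyl on a nitrogen on an aromatic ring. Going by the values given here, no measured pair shows this change, so the size of the step is open; a small step in either direction, not clearly beyond the scatter, is expected. For compound 4 in this assay the estimate is 55%, between 30% and 80%, which means an expected step of a number 3 percentage points higher from compound 3 to compound 4 (within the scatter).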

Compound 4, a percentage reported as inhibition, at one concentration (the size of the read-out at that concentration, not a potency): 33%
Beside the measured number, compound 4's estimate is 22 percentage points above it; measured number inside the range.
By their numbers in this assay, from the lowest: compound 4; then compounds 3, 2 and 1 (each within the scatter of the next, the first and the last beyond it).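

In this assay, going by these compounds alone, the substituent on a nitrogen on an aromatic ring proves able to shift the read-out: 3-phenylpropyl in place of cyclobutylcarbonyl gives a number 19 percentage points lower from compound 3 to compound 4 (beyond the scatter) and is the first step measured at this position. The change removes the carbonyl and the four-membered ring and adds a six-membered aromatic ring in one move, so the contribution of each part cannot be separated. No supporting evidence explains the drop.

Open, as far as these compounds go, is whether 3-phenylpropanoyl, which restores the carbonyl, recovers the number of compound 3. Also open, from the compounds shown here alone, is how benzyl or a longer chain such as 4-phenylbutyl behaves at this nitrogen.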